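Swapping cyclohexyl for 2,6-dimethylphenyl on the side chain

The source may hold more compounds than are shown below. What is called first, only, known or untested is meant among the compounds shown, and "the series" means these compounds.

Compound 1 `C=C(CCC1CCCCC1)C(O)Cc1c(O)cc(C)c(C=O)c1O` gives 8430 nM in a functional assay on EC17 cells (Homo sapiens) for inhibition, with a stated time of 24 h; on this read-out lower numbers stand for stronger inhibition and higher numbers for weaker inhibition.
Compound 2 `C=C(C)C(O)Cc1c(O)cc(C)c(C=O)c1O` gives 30000 nM in this assay.

Compound 1 holds the lower of the two numbers; its nearest neighbour is compound 2, and the step of a 3.6-fold higher number from compound 1 to compound 2 (0.55 log units; beyond the scatter) shows that the cyclohexylmethyl group contributes modestly to inhibition in this assay. Compound 3 `C=C(CCc1c(C)cccc1C)C(O)Cc1c(O)cc(C)c(C=O)c1O` differs from compound 1 by 2,6-dimethylphenyl in place of cyclohexyl on a saturated chain carbon, two bonds along the chain from a double-bonded chain carbon. Going by the values given here, no measured step exchanges one ring for another at this position, so the only bearing is indirect: the step from compound 1 to compound 2 indicates that a substituent here matters, but not whether a saturated or an aromatic ring is preferred. Compound 3 is therefore expected to land close to compound 1, with a step of about a 1.1-fold lower number from compound 1 to compound 3 (0.05 log units; within the scatter) that may fall within the scatter. The estimate for compound 3 is 7500 nM, ranging from 2500 nM to 22000 nM.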

Compound 3, half-maximal inhibitory concentration: 10600 nM
For compound 3 the middle estimate is 1.4-fold (0.15 log units) below the measured one; the measured number falls inside the stated range.
By their numbers in this assay, from the lowest: compounds 1 and 3 (each within the scatter of the next); then compound 2.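

In this assay the exchange of rings gives a 1.3-fold higher number from compound 1 to compound 3 (0.10 log units; within the scatter), so 2,6-dimethylphenyl and cyclohexyl on this saturated chain carbon cannot be told apart by their numbers. Going by these compounds alone, the earlier step, a 3.6-fold higher number from compound 1 to compound 2 (0.55 log units; beyond the scatter), showed only that removing the cyclohexylmethyl group from the chain matters; the new pair adds that the saturated ring is not required to keep a number in the range of compound 1, and that an aromatic ring with two more carbon atoms serves within the scatter. No measured information on these compounds accounts for this result.

The compounds shown leave open whether a ring is needed here at all, or whether a plain longer chain would read the same. They also leave open how unsubstituted phenyl, or a ring carrying an amine or a carboxylic acid, would read at this position.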